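A bromo swap where three compounds already sit flat

The source may report more compounds than this note shows. Statements on the series, on what has been measured and on what is new or still open speak of the compounds shown alone.

Of the compounds shown here, three have been measured in an assay on CHO cells for displacement of a labelled ligand from adenosine receptor A1 (Homo sapiens), read by scintillation counting, tested at 10 uM; a lower number here means less inhibition, a higher number more inhibition at the concentration tested (going by the name of the read-out). Compound 1 `CC(C)(C)c1csc(N)c1C(=O)c1ccc(Cl)cc1` gives 1%. Compound 2 `CC(C)(C)Cc1c(-c2ccncc2)sc(N)c1C(=O)c1ccc(Cl)cc1` gives 1%, and compound 3 `CC(C)(C)Cc1c(-c2c(F)cccc2F)sc(N)c1C(=O)c1ccc(Cl)cc1` gives 1%. Compound 2 therefore stands level with compound 1 and with compound 3 at the digits shown, all three within the scatter of one another. Compound 4 `CC(C)(C)Cc1c(Br)sc(N)c1C(=O)c1ccc(Cl)cc1` differs from compound 2 by bromo in place of pyridin-4-yl on an aromatic carbon. For the measured compounds named here, the only measured step on the same carbon, no change at the digits printed from compound 2 to compound 3 (within the scatter), bears on this change and was no change at all. Compound 4 is expected to show no step beyond the scatter either, a number 1 percentage points higher from compound 2 to compound 4 (within the scatter). Compound 4 is thus estimated at 2%, within -8% to 12%.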

Compound 4, a percentage reported as inhibition, at one concentration (the size of the read-out at that concentration, not a potency): 1%
Compound 4: the middle estimate sits 1 percentage points above what was measured; the measured number falls inside the stated range.
By their numbers in this assay, from the lowest: compounds 1, 2, 3 and 4 (each within the scatter of the next).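

Bromo on the aromatic carbon next to the ring sulfur gives, in this assay, no change at the digits printed from compound 2 to compound 4 (within the scatter), and in place of 2,6-difluorophenyl it gives no change at the digits printed from compound 3 to compound 4 (within the scatter). This position therefore reads the same with no ring on it as with either aromatic ring, and removing the pyridin-4-yl hydrogen-bond acceptor moves nothing. No other data explain this flat result. With every value at the same level, these compounds cannot show whether anything at this carbon can raise the inhibition. From the compounds shown here alone, whether an amine or a carboxylic acid there would do so remains open.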